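Thiophen-2-yl in place of 2-fluorophenyl: compound 1 to compound 4

The source may report more compounds than this note shows. Statements on the series, on what has been measured and on what is new or still open speak of the compounds shown alone.

In a physicochemical assay for pharmacokinetics (on this read-out higher numbers stand for a longer-lived compound and lower numbers for a shorter-lived compound), compound 1 (`O=C(NCc1ccccc1F)N1C(=O)c2ccccc2S1(=O)=O`) gives > 166 h as its reading, which is a limit and not a number. Compound 2 (`O=C(CCc1ccccc1)N1C(=O)c2ccccc2S1(=O)=O`) gives > 166 h as its reading, which is also a limit. Compound 3 (`O=C(c1ccccc1)N1Cc2ccccc2C1=O`) gives > 166 h as its reading, again a limit. Among the measured compounds shown here, compound 1 therefore stands with the other two at the limit of > 166 h in this assay, at which 3 of the 3 values shown sit, and no measured step links any of them.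

Compound 4 (`O=C(NCc1cccs1)N1C(=O)c2ccccc2S1(=O)=O`) has not yet been measured. It differs from compound 1 in one place (thiophen-2-yl in place of 2-fluorophenyl on a saturated chain carbon bound to an amide-type nitrogen) with thiophen-2-yl in place of 2-fluorophenyl on a saturated chain carbon bound to an amide-type nitrogen, while the shared core stays unchanged.

For the measured compounds named here, with no measured step to go by, no change beyond the usual scatter is expected in this assay, and no direction is favoured. This expectation rests on compound 1 and its reading of > 166 h as a limit. The estimated change (a number no higher from compound 1 to compound 4 (the limit leaves the size open)) is expected to stay small, and the reading may well arrive as a limit once more. Compound 4 is expected at 166 h (estimated range 80 h to 340 h).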

Compound 4, half-life: > 166 h
Compound 4 was reported as a limit (the forecaster's own chance of this, stated with the estimate: 75%); the middle value lies on the limit itself.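

Among the compounds shown here, compound 1 and compound 4 are both reported as limits in this assay, so no step between compound 1 and compound 4 can be read: the limit of > 166 h in this assay, at which 4 of the 4 values shown sit. The compounds shown leave open what the half-life of any of them actually is, and whether thiophen-2-yl and 2-fluorophenyl differ at all on this read-out.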